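Butyl for Cyclohexyl on the Amide Nitrogen of Compound 3

This account rests on a few compounds, and the source may have more. Where it says the series, first, only, none or still open, it means among the compounds named here.

Measured compounds and their values:
- compound 1, `O=C(CCCCCN(C(=O)c1ccccc1)C1(C(=O)NC2CCCCC2)CCCCC1)NO`: 42600 nM
- compound 2, `CC(C)(C)NC(=O)C(C)(C)N(CCCCCC(=O)NO)C(=O)c1ccccc1`: 207000 nM
- compound 3, `CN(C)c1ccc(C(=O)N(CCCCCC(=O)NO)CC(=O)NC2CCCCC2)cc1`: 1540 nM

All three were tested in a functional assay on A2780 cells (Homo sapiens) for cytotoxicity, read by MTT assay, with a stated time of 72 h; on this read-out lower numbers stand for stronger inhibition and higher numbers for weaker inhibition. Compound 3, with the structure `CN(C)c1ccc(C(=O)N(CCCCCC(=O)NO)CC(=O)NC2CCCCC2)cc1`, gives 1540 nM, which is the lowest of the three numbers; the gaps from compound 3 to compound 1 and to compound 2 are both beyond the usual scatter, so compound 3 is the most potent of the measured set. Compound 1 gives 42600 nM, and compound 2 gives 207000 nM.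

The new compound is compound 4, `CCCCNC(=O)CN(CCCCCC(=O)NO)C(=O)c1ccc(N(C)C)cc1`. It differs from compound 3 in one place: butyl in place of cyclohexyl on an amide-type nitrogen. Among the compounds with values here, no step between two measured compounds carries this same change, so there is nothing directly comparable in the measured set; the cyclohexyl group is also present in compound 1, but compound 1 differs from compound 3 in more than one place.

The expectation for compound 4 is a small weakening, probably not far beyond the scatter, with a step of a 1.6-fold higher number from compound 3 to compound 4 (0.21 log units; within the scatter) from compound 3. Compound 4 is expected to give about 2500 nM in this assay, in a range from 800 nM to 8000 nM.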

Compound 4, half-maximal inhibitory concentration: 1900 nM
Estimate against measurement, compound 4: 1.3-fold (0.12 log units) above; the measured number falls inside the stated range.
By their numbers in this assay, from the lowest: compounds 3 and 4 (each within the scatter of the next); then compound 1; then compound 2.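

In this assay, butyl in place of cyclohexyl on the amide-type nitrogen gives a 1.2-fold higher number from compound 3 to compound 4 (0.09 log units; within the scatter), so the two compounds cannot be told apart on this read-out. Within the data shown here, this is the first direct look at this position, since no two of the earlier compounds differed in only one place, and it shows that the cyclohexyl ring itself is not required here to keep the number where compound 3 has it: an open butyl chain, with fewer heavy atoms and no ring, serves as well on this core. Nothing available explains why so large a change in shape leaves the number in place.

Going by these compounds, whether the position stays this forgiving for a longer chain such as octyl, for a phenyl ring, or for a butyl chain ending in an amine or a carboxylic acid remains open. Also open, on these data alone, is whether the same swap gives so small a step on the core of compound 1, which carries cyclohexyl on the same kind of nitrogen, and whether it holds in any read-out other than this assay.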